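The source may hold more compounds than are shown below. What is called first, only, known or untested is meant among the compounds shown, and "the series" means these compounds.

Compound 1 `O=C1c2ccc(OCc3cccc(-c4ccc(Cl)cc4F)c3)cc2CN1C1CCCC1` carries the shared core, but in an assay on HEK293 cells for positive allosteric modulation of metabotropic glutamate receptor 2 (Rattus norvegicus), read by thallium flux (on this read-out higher numbers stand for larger maximal responses and lower numbers for smaller maximal responses), compound 1 has "not determined" (no result reported). For the measured compounds named here, compound 2 `O=C(O)c1cc(-c2cccc(COc3ccc4c(c3)CN(C3CCCC3)C4=O)c2)ccc1O` gives 90.1% in this assay, and compound 3 `COc1ccc(-c2cccc(COc3ccc4c(c3)CN(C3CCCC3)C4=O)c2)cc1C(=O)O` gives 78%, the lower of the two numbers; the only measured step, a number 12.1 percentage points lower from compound 2 to compound 3 (beyond the scatter), is a modest one. Compound 4 `O=C(O)c1ccc(-c2cccc(COc3ccc4c(c3)CN(C3CCCC3)C4=O)c2)c(Cl)c1` differs from compound 3 in one place: 4-carboxy-2-chlorophenyl in place of 3-carboxy-4-methoxyphenyl on an aromatic carbon. Going by the values given here, no measured step involves chlorine or a 4-carboxy-2-chlorophenyl group, so the one step from compound 2 to compound 3 bears only loosely on this change. The step of a number 4 percentage points higher from compound 3 to compound 4 (within the scatter) is therefore expected to stay within the usual scatter. Compound 4 is estimated at 82% in this assay, within a range from 65% to 98%.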

Compound 4, largest response reached (reported as percent of maximum), in percent of the reference or control that the assay uses: 89.4%
Compound 4: middle estimate off by 7.4 percentage points, on the low side; the measured number falls inside the stated range.
By their numbers in this assay, from the lowest: compound 3; then compounds 4 and 2 (each within the scatter of the next).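

The change from 3-carboxy-4-methoxyphenyl to 4-carboxy-2-chlorophenyl gives a number 11.4 percentage points higher from compound 3 to compound 4 (beyond the scatter) in this assay. Set against 3-carboxy-4-hydroxyphenyl, the same group gives a number 0.7 percentage points lower from compound 2 to compound 4 (within the scatter), so this position carries a carboxy-substituted ring with a chlorine and no hydroxyl at a response level matching that of compound 2. Nothing measured here accounts for either step. Still open, from the compounds shown here alone, is what an amide or a tetrazole in place of the carboxylic acid would give on this ring, and what bromine or a methyl group would give in place of the chlorine.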